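Swapping an Alkyl Chain for an Amide at the Ring Nitrogen

This account rests on a few compounds, and the source may have more. Where it says the series, first, only, none or still open, it means among the compounds named here.

Compound 1 `CCN1CCN(C(=O)C[C@H](Cc2ccc(Cl)cc2)C(=O)N2CCN(c3ccccc3N(CC3CC3)S(C)(=O)=O)CC2)CC1`: in a functional assay with Melanocortin receptor 4 (Homo sapiens) as the target, read by cAMP accumulation (on this read-out higher numbers stand for an effect only at larger amounts of compound and lower numbers for an effect already at smaller amounts), compound 1 gives > 10000 nM, which is a limit of the assay and not a number.
Compound 2 `CC(C)CCN1CCN(C(=O)C[C@H](Cc2ccc(Cl)cc2)C(=O)N2CCN(c3ccccc3N(CC3CC3)S(C)(=O)=O)CC2)CC1`: in this assay compound 2 gives > 10000 nM, again only a limit.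

Going by the values given here, compound 2 therefore stands at the limit of this assay, and so does compound 1; the one measured step, a step that the two limits leave unreadable from compound 1 to compound 2, cannot be read in size or direction, since (the limit of > 10000 nM in this assay, at which 2 of the 2 values shown sit).

Compound 3 `CC(C)(C)CC(=O)N1CCN(C(=O)C[C@H](Cc2ccc(Cl)cc2)C(=O)N2CCN(c3ccccc3N(CC3CC3)S(C)(=O)=O)CC2)CC1` differs from compound 2 by neopentylcarbonyl in place of isopentyl on an amine nitrogen in a ring. No measured step bears on this change in a readable way, so no direction beyond the scatter can be expected from the data shown. Compound 3 is therefore estimated at 10000 nM, with a range from 2000 nM to 50000 nM, most likely reported once more as a limit. The step expected from compound 2 to compound 3 is a number no higher from compound 2 to compound 3 (the limit leaves the size open).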

Compound 3, half-maximal effective concentration: 74 nM
Compound 3: the middle estimate sits 140-fold (2.13 log units) above what was measured, and the stated range ends above it.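

In this assay, the ring nitrogen proves to be a place where a single change can matter greatly: neopentylcarbonyl in place of isopentyl gives an at least 130-fold lower number from compound 2 to compound 3 (2.13 log units; beyond the scatter), and neopentylcarbonyl in place of ethyl gives an at least 130-fold lower number from compound 1 to compound 3 (2.13 log units; beyond the scatter). Going by these compounds alone, compounds 1 and 2 could not show this, since the step between those two alkyl compounds cannot be read, whereas compound 3 gives the only actual number so far. The entering group also turns the ring nitrogen into an amide, so the carbonyl now appears as a feature that travels with the large drop in the number.

As far as these compounds go, both steps start from a limit, so their full size stays open: the limit of > 10000 nM in this assay, at which 2 of the 3 values shown sit. Whether the carbonyl or the rest of the neopentyl chain accounts for the change also stays open, and a small acetyl group or a urea at this nitrogen would bear on that question.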